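Replacing pyridin-2-yl with 3-chlorophenyl at the assay limit

A few compounds are considered here, and "the series" means these few. Any claim that something is new, unique, unknown or untested is made for them only; others in the source may bear on it.

In a functional assay on MDA-MB-468 cells (Homo sapiens) for antiproliferative activity, read by MTT assay, with a stated time of 72 h (on this read-out lower numbers stand for stronger inhibition and higher numbers for weaker inhibition), compound 2 (`O=C(Nc1ccc(Cl)c(-c2nnc3c(Cl)cccn23)c1)c1ccccn1`) gives > 100000 nM as a limit of the assay and not a number. Compound 4 (`O=C(Nc1ccc(Cl)c(-c2nnc3c(Cl)cccn23)c1)c1cccc(Cl)c1`) puts 3-chlorophenyl in place of pyridin-2-yl on a carbonyl carbon and has not yet been measured.

Going by the values given here, the only measured step at that place is a step that the two limits leave unreadable from compound 2 to compound 3 and offers no size to carry over. Compound 3 (`Cc1nc(C(=O)Nc2ccc(Cl)c(-c3nnc4c(Cl)cccn34)c2)cs1`) gives > 100000 nM as a limit of the assay. Compound 1 (`O=C(Nc1ccc(Cl)c(-c2nnc3c(Cl)cccn23)c1)c1ccc(C(F)(F)F)cc1Cl`) also has an aromatic ring of carbon only on the carbonyl carbon and gives > 100000 nM as a limit of the assay. Taken together, the evidence so far is the limit of > 100000 nM in this assay, at which 3 of the 3 values shown sit, and no compound in the set yet has a true number.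

With nothing but limits to go on, no step beyond the scatter is expected in this assay and no direction can be argued. The expected result is a number no higher from compound 2 to compound 4 (the limit leaves the size open) and a report of only a limit is the likeliest outcome. Compound 4 is estimated at 100000 nM with 30000 nM to 150000 nM as the expected range.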

Compound 4, half-maximal inhibitory concentration: 54800 nM
Beside the measured number, compound 4's estimate is 1.8-fold (0.26 log units) above it; low and high end bracket the measured number.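

In this assay, going by these compounds alone, compound 4 is the first compound in the set to give a true number and not a limit, so this place on the carbonyl carbon now has one measured point. As far as these compounds go, putting 3-chlorophenyl in place of pyridin-2-yl gives an at least 1.8-fold lower number from compound 2 to compound 4 (0.26 log units; that floor lies within the scatter), and putting it in place of 2-methyl-1,3-thiazol-4-yl gives an at least 1.8-fold lower number from compound 3 to compound 4 (0.26 log units; that floor lies within the scatter); each of these is only a floor, since the starting value is a limit, so the real size of either step stays unknown. Compound 1, which also has an aromatic ring of carbon only on the carbonyl carbon, gives > 100000 nM, a limit of the assay, so such a ring alone does not bring a true number: the limit of > 100000 nM in this assay, at which 3 of the 4 values shown sit.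

The step between the two limits, from compound 2 to compound 3, cannot be read, and a single true number cannot show what part the chlorine of the 3-chlorophenyl group plays. From the compounds shown here alone, it also remains open how a phenyl ring without chlorine, a cyclohexyl group, or a ring carrying an amine or a carboxylic acid would read at this place in this assay.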